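This account rests on a few compounds, and the source may have more. Where it says the series, first, only, none or still open, it means among the compounds named here.

Measured compounds in a functional assay on MCF7 cells (Homo sapiens) for antiproliferative activity, read by MTT assay, with a stated time of 72 h; a lower number here means a stronger inhibitor, a higher number a weaker inhibitor:
- compound 1 `COc1ccc(/C=C2/CN(C)/C(=N/c3ccc(C)cc3)S2)cc1` gives 7600 nM.
- compound 2 `COc1ccc(/C=C2\S/C(=N\c3ccccc3)N(C)C2=O)cc1` gives only a limit, > 100000 nM.
- compound 3 `COc1ccc(/C=C2\S/C(=N\c3cc(C(F)(F)F)cc(C(F)(F)F)c3)N(C)C2=O)cc1` gives 77800 nM.

Compound 2 stands at the limit of this assay rather than at a number, the point at which (the limit of > 100000 nM in this assay, at which 1 of the 3 values shown sits). For the measured compounds named here, compound 3, which carries a bis-trifluoromethylphenyl on the same core, is the only compound of that core with a number. Compound 1 has a different core and a methylphenyl, and its value is the lowest shown; it sets no step to compound 2 or compound 3 that can be measured here, so the comparison is left at what the two values show.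

The next compound, compound 4 `C=CC/N=C1\S/C(=C\c2ccc(OC)cc2)C(=O)N1C`, keeps the core of compound 2 and changes one group: allyl in place of phenyl on a double-bonded nitrogen

Going by the values given here, no measured step matches this change, so the direction is not fixed by the data. With compound 2 at a limit, the step can only be guessed: in this assay a movement of modest size in either direction, or none beyond the scatter, is all that can be expected. Compound 4 is estimated at 80000 nM, between 20000 nM and 300000 nM, which means an expected step of an at least 1.2-fold lower number from compound 2 to compound 4 (0.09 log units; that floor lies within the scatter).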

Compound 4, half-maximal inhibitory concentration: > 100000 nM
Compound 4: a limit, no number; the forecaster's own chance of this, stated with the estimate: 45%; middle value at least 1.2-fold (0.09 log units) away from the limit.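

In this assay, compound 2 and compound 4 each give only a limit and no number, so no step can be read between them: the limit of > 100000 nM in this assay, at which 2 of the 4 values shown sit.

The compounds shown leave open whether allyl in place of phenyl on a double-bonded nitrogen changes activity on the shared core at all.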